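A few compounds are considered here, and "the series" means these few. Any claim that something is new, unique, unknown or untested is made for them only; others in the source may bear on it.

Values in a toxicity assay on HT-29 cells (Homo sapiens) for cytotoxicity (a lower number here means that less compound is tolerated, a higher number that more compound is tolerated), follow
Compound 1 `CC(C)CCn1nc(C(=O)N[C@H]2COc3ccccc3N(C)C2=S)nc1Cc1ccccc1` gives > 100000 nM as a limit
Compound 2 `CN1C(=S)[C@@H](NC(=O)c2nc(Cc3ccccc3)n(CCCO)n2)COc2ccccc21` gives > 100000 nM as a limit

Compound 2 stands at > 100000 nM as a limit and not a number. The evidence so far is the limit of > 100000 nM in this assay, at which 2 of the 2 values shown sit, and no more. Compound 3 `CN1C(=S)[C@@H](NC(=O)c2nc(Cc3ccccc3)n(C3CCCC3)n2)COc2ccccc21` carries the change cyclopentyl in place of 3-hydroxypropyl on an aromatic nitrogen on the shared core. Within the data shown here, with a step that the two limits leave unreadable from compound 1 to compound 2 as the only measured step and no size to carry over, no step beyond the scatter is expected in this assay in either direction. The expected step is a number no higher from compound 2 to compound 3 (the limit leaves the size open) on this reading. Compound 3 is estimated at 100000 nM with an expected range of 30000 nM to 200000 nM in this assay.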

Compound 3, half-maximal cytotoxic concentration: > 100000 nM
Compound 3 gave a limit, no number; the forecaster's own chance of this, stated with the estimate: 80%; the middle value sits exactly at the limit.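

No new step can be read in this assay, since compound 1, compound 2 and compound 3 all stand at a limit and not a number: the limit of > 100000 nM in this assay, at which 3 of the 3 values shown sit.

From the compounds shown here alone, whether any group on the aromatic nitrogen of the shared core shifts the half-maximal cytotoxic concentration remains open.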